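This account rests on a few compounds, and the source may have more. Where it says the series, first, only, none or still open, it means among the compounds named here.

Measured so far in an assay on isolated protein for inhibition of glucose-6-phosphatase catalytic subunit 1 (Homo sapiens), read by inositol phosphate accumulation, with a stated time of 30 min, tested at 100 uM; on this read-out higher numbers stand for more inhibition at the one concentration tested (going by the name of the read-out) and lower numbers for less inhibition:

- compound 1 `CC1(C)CC(=O)C2=C(C1)NC(C(=O)O)=CC2c1ccccc1`: 17.1%
- compound 2 `CC1(C)CC(=O)C2=C(C1)NC(c1ccccc1)=CC2c1ccccc1`: "not active" (no number reported)
- compound 3 `COc1ccc(C2=CC(c3ccccc3)C3=C(CC(C)(C)CC3=O)N2)cc1`: 8.34%

Compound 3 holds the lower of the two numbers recorded in this assay; its nearest neighbour is compound 1, and the step of a number 8.8 percentage points lower from compound 1 to compound 3 (within the scatter) lies within the scatter, so the two cannot be ordered. Compound 2, with phenyl in the same position, has no number at all in this assay.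

Compound 4 `CCOC(=O)C1=CC(c2ccccc2)C2=C(CC(C)(C)CC2=O)N1` is not yet measured. The change from compound 3 is ethoxycarbonyl in place of 4-methoxyphenyl on a double-bonded ring carbon. Going by the values given here, the only measured step at this position is a number 8.8 percentage points lower from compound 1 to compound 3 (within the scatter), which exchanged carboxy for 4-methoxyphenyl without moving the number beyond the scatter; compound 2 adds that phenyl at the same position gave no reportable activity. Among the compounds with values here, nothing measured so far separates substituents at this carbon, so the step of a number 3.7 percentage points higher from compound 3 to compound 4 (within the scatter) is expected to stay within the scatter, in no particular direction.

Compound 4 is therefore estimated at 12% in this assay, with a range from 0% to 28%. There is also a fair chance that, as for compound 2, no number is returned and the result is only reported as not active.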

Compound 4, a percentage reported as inhibition, at one concentration (the size of the read-out at that concentration, not a potency): "not active" (no number reported)
Compound 4: no number reported; there is nothing to compare the estimate with.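

Going by these compounds alone, compound 4, like compound 2, is reported in this assay only as not active, without a number, so no step from compound 3 to compound 4 can be read. The compounds shown leave open whether the substituents at this double-bonded ring carbon differ in inhibition. No measured evidence bears on this result.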